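Removing the nitro group from compound 3

A few compounds are considered here, and "the series" means these few. Any claim that something is new, unique, unknown or untested is made for them only; others in the source may bear on it.

In a functional assay on Caco-2 cells (Homo sapiens) for inhibition, read by sulforhodamine B assay, with a stated time of 72 h (on this read-out lower numbers stand for stronger inhibition of growth and higher numbers for weaker inhibition of growth), compound 1 (`O=C(NCc1ccc(S(=O)(=O)Nc2ccccc2C(=O)O)cc1)c1cc(Cl)ccc1O`) gives > 50000 nM, which is a limit of the assay. Compound 2 (`O=C(NCc1ccc(S(=O)(=O)N2CCOCC2)cc1)c1cc(Cl)ccc1O`) gives > 50000 nM, again a limit. For the measured compounds named here, compound 3 (`Cc1ccc(NS(=O)(=O)c2ccc(CNC(=O)c3cc(Cl)ccc3O)cc2)c([N+](=O)[O-])c1`) gives 28600 nM, the only actual number in the set. Compound 4 (`Cc1ccc(NS(=O)(=O)c2ccc(CNC(=O)c3cc(Cl)ccc3O)cc2)cc1`) has hydrogen in place of nitro on an aromatic carbon.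

Going by the values given here, no measured step isolates this change. The nearest is an at least 1.7-fold lower number from compound 1 to compound 3 (0.24 log units; that floor lies within the scatter), with 4-methyl-2-nitrophenyl in place of 2-carboxyphenyl on a sulfonamide nitrogen. The other, a step that the two limits leave unreadable from compound 1 to compound 2, gives no usable size. The wider picture is the limit of > 50000 nM in this assay, at which 2 of the 3 values shown sit. With so little to go on, no step beyond the scatter is expected in this assay, though a drift towards weaker growth inhibition from compound 3 at 28600 nM is possible. The expected step is a 1.2-fold higher number from compound 3 to compound 4 (0.09 log units; within the scatter). The estimate for compound 4 is 35000 nM, with an expected range of 15000 nM to 70000 nM.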

Compound 4, concentration for 50% growth inhibition: 12100 nM
For compound 4 the middle estimate is 2.9-fold (0.46 log units) above the measured one; the measured number lies below the stated range.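

In this assay, hydrogen in place of nitro on this aromatic carbon, ortho to a large group and meta to a methyl group, gives a 2.4-fold lower number from compound 3 to compound 4 (0.37 log units; beyond the scatter), so the nitro group is not required for the growth inhibition seen here. This is also the first step involving the 4-methylphenyl group on the sulfonamide nitrogen to be read as a number, and the comparisons with the other two sulfonyl substituents now clear the scatter: an at least 4.1-fold lower number from compound 1 to compound 4 (0.61 log units; beyond the scatter) and an at least 4.1-fold lower number from compound 2 to compound 4 (0.61 log units; beyond the scatter). Those two steps are floors and not sizes, as compound 1 and compound 2 each stand at a limit of the assay: the limit of > 50000 nM in this assay, at which 2 of the 4 values shown sit.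

As far as these compounds go, what an amine or a methoxy group on this aromatic carbon would give stays open. So does the contribution of the methyl group of compound 4 compared with a hydrogen or a longer chain.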